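Carboxymethyl Replaces Benzyl on a Nucleoside Sulfide

The source may hold more compounds than are shown below. What is called first, only, known or untested is meant among the compounds shown, and "the series" means these compounds.

The starting point is compound 1 `OC[C@H]1O[C@@H](n2cnc3c(CSCc4ccccc4)ncnc32)[C@H](O)[C@@H]1O`, a nucleoside carrying a benzylsulfanyl group on its core. In a functional assay on Huh-7 cells (Homo sapiens) for cytotoxicity, read by MTT assay, with a stated time of 3 days (on this read-out lower numbers stand for higher toxicity in this test and higher numbers for lower toxicity in this test), compound 1 gives > 100000 nM, which is a limit of the assay and not a measured number. Two close relatives have been tested in the same way. Compound 2 `COCc1ncnc2c1ncn2[C@@H]1O[C@H](CO)[C@@H](O)[C@H]1O` gives > 100000 nM, again a limit. Compound 3 `OCCSCc1ncnc2c1ncn2[C@@H]1O[C@H](CO)[C@@H](O)[C@H]1O` gives > 100000 nM, also a limit. Because all three sit at the limit of > 100000 nM in this assay, at which 3 of the 3 values shown sit, the steps between them cannot be sized: a step that the two limits leave unreadable from compound 1 to compound 2, a step that the two limits leave unreadable from compound 1 to compound 3 and a step that the two limits leave unreadable from compound 2 to compound 3 remain unreadable, so no change in cytotoxicity has yet been seen across this small set.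

The compound still to be tested is compound 4 `O=C(O)CSCc1ncnc2c1ncn2[C@@H]1O[C@H](CO)[C@@H](O)[C@H]1O`. It differs from compound 1 by carboxy in place of phenyl on a saturated chain carbon bound to a sulfur. The most comparable earlier change is that from compound 1 to compound 3, which swapped the same phenyl for a hydroxymethyl and left the read-out at the limit; the step to compound 4 is therefore expected to show nothing beyond the scatter, a step that the limit leaves unreadable from compound 1 to compound 4. Compound 4 is accordingly estimated at 150000 nM, within a range from 50000 nM to 500000 nM, with the assay most likely reporting only a limit once more.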

Compound 4, half-maximal cytotoxic concentration: > 100000 nM
Compound 4 was reported as a limit; the forecaster's own chance of this, stated with the estimate: 85%; the middle value does not contradict the limit.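

In this assay compound 4 gives > 100000 nM, which is again a limit and not a measured number. Its steps from compound 1, compound 2 and compound 3 therefore cannot be read, as all four compounds share the same limit: the limit of > 100000 nM in this assay, at which 4 of the 4 values shown sit.

The compounds shown leave open whether any change on the shared core would give a measurable cytotoxic concentration.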